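A few compounds are considered here, and "the series" means these few. Any claim that something is new, unique, unknown or untested is made for them only; others in the source may bear on it.

In an ADME assay on HEK293 cells (Homo sapiens) for cytotoxicity, read by MTT assay, with a stated time of 72 h (on this read-out lower numbers stand for stronger inhibition and higher numbers for weaker inhibition), compound 1 (`O=C(CN1CCN(C(=O)c2ccccc2)CC1)N1CCN(CCCc2c[nH]c3ccccc23)CC1`) gives only a limit of the assay, > 200000 nM. Compound 2 (`COc1ccc(C(=O)N2CCN(CC(=O)N3CCN(CCCc4c[nH]c5ccccc45)CC3)CC2)cc1`) gives a measured number, 156000 nM. Compound 3 (`COc1ccc2[nH]cc(CCCN3CCN(C(=O)CN4CCN(C(=O)c5ccccc5)CC4)CC3)c2c1`) is also reported only as a limit, > 200000 nM. It therefore has no number of its own and stands at the limit of > 200000 nM in this assay, at which 2 of the 3 values shown sit.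

Compound 4 (`COc1ccc(C(=O)N2CCN(CC(=O)N3CCN(CCCc4c[nH]c5ccc(OC)cc45)CC3)CC2)cc1`) differs from compound 3 by a single change, methoxy in place of hydrogen on an aromatic carbon, which turns benzoyl into (4-methoxyphenyl)carbonyl.

Two measured steps made the same kind of exchange. The closer one, on the benzoyl side, is an at least 1.2-fold lower number from compound 1 to compound 2 (0.10 log units; that floor lies within the scatter). The other, made elsewhere in the shared core, is a step that the two limits leave unreadable from compound 1 to compound 3. Neither shows a change beyond the scatter, so the evidence supports only a modest expectation. The number for compound 4 is expected to land near that of compound 2, 156000 nM. The number for compound 4 could still fall at the limit of the assay.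

The expected step is an at least 1.2-fold lower number from compound 3 to compound 4 (0.09 log units; that floor lies within the scatter), toward a lower number, and it is not expected to stand clear of the scatter. The estimate for compound 4 is 160000 nM, with an expected range of 90000 nM to 280000 nM.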

Compound 4, half-maximal inhibitory concentration: 190000 nM
The estimate for compound 4 lay 1.2-fold (0.07 log units) below the measured number; the measured number falls inside the stated range.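

Compound 4 gives the series a number where compound 3 gave only a limit, and the 4-methoxyphenyl exchange on a core already carrying a methoxy elsewhere amounts to an at least 1.0-fold lower number from compound 3 to compound 4 (0.02 log units; that floor lies within the scatter). The methoxy made elsewhere in the shared core, whose step from compound 1 to compound 3 could not be read, now has a readable step with the 4-methoxyphenyl group in place: a 1.2-fold higher number from compound 2 to compound 4 (0.09 log units; within the scatter). So neither methoxy moves the number in this assay beyond the scatter on these cores, and the exchange on the benzoyl side looks much alike on both, although the limits leave the comparison incomplete: the same change on two cores in this assay, an at least 1.2-fold lower number (0.10 log units; that floor lies within the scatter) from compound 1 to compound 2 and an at least 1.0-fold lower number (0.02 log units; that floor lies within the scatter) from compound 3 to compound 4; the limit leaves it open whether they differ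

From the compounds shown here alone, the true size of both steps from the unsubstituted compounds stays open, as only a floor can be given for each: the limit of > 200000 nM in this assay, at which 2 of the 4 values shown sit. Also open is whether an amine or a carboxylic acid in place of the methoxy on the 4-methoxyphenyl group would shift the number in this assay clear of the scatter.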